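The source may hold more compounds than are shown below. What is called first, only, known or untested is meant among the compounds shown, and "the series" means these compounds.

Working notes on the series. In a functional assay on BT-549 cells (Homo sapiens) for cytotoxicity, read by MTT assay, with a stated time of 48 h (a lower number here means a stronger inhibitor, a higher number a weaker inhibitor), compound 1 `CCn1c(/C=C2/C(=O)Nc3ccccc32)nc2ccccc21` gives > 50000 nM, which is a limit of the assay and not a number. In this assay compound 2 `CCn1c(/C=C2/C(=O)Nc3ccc(C)cc32)nc2ccccc21` gives > 50000 nM, again a limit of the assay and not a number. The step that the two limits leave unreadable from compound 1 to compound 2, methyl in place of hydrogen on an aromatic carbon, cannot be sized because of the limit of > 50000 nM in this assay, at which 2 of the 3 values shown sit.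

Compound 3 `Cn1c(/C=C2/C(=O)Nc3ccc([N+](=O)[O-])cc32)nc2ccccc21` has no single number in this assay; its entry reads "not determined" (no result reported). Among the measured compounds shown here, the only other values shown for the series are the two limits just given. Compound 4 `Cn1c(/C=C2/C(=O)Nc3ccc(F)cc32)nc2ccccc21` differs from compound 3 by fluoro in place of nitro on an aromatic carbon. For the measured compounds named here, no measured step bears directly on fluoro in place of nitro on an aromatic carbon, and the one measured step, methyl in place of hydrogen, is itself unreadable between two limits. There is thus no measured change on which to build a direction or size for compound 4 in this assay.

The expectation rests on the two limits alone. With both measured members of the series at the limit, compound 4 is expected to give about 60000 nM, within a range from 15000 nM to 250000 nM, most likely reported only as a limit again.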

Compound 4, half-maximal inhibitory concentration: 26900 nM
Estimate against measurement, compound 4: 2.2-fold (0.35 log units) above; the range from low to high includes it.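

In this assay compound 4 gives 26900 nM, but compound 3 has no single number, so no step can be read from compound 3 to compound 4. Left open are the size and direction of fluoro in place of nitro on an aromatic carbon, and how far the compounds at the limit lie past it: the limit of > 50000 nM in this assay, at which 2 of the 4 values shown sit.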